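This account rests on a few compounds, and the source may have more. Where it says the series, first, only, none or still open, it means among the compounds named here.

Of the compounds shown here, two sharing one core have been measured in an assay on isolated protein for inhibition of beta-glucuronidase (Bos taurus), read by spectrophotometry, with a stated time of 30 min; on this read-out lower numbers stand for stronger inhibition and higher numbers for weaker inhibition. Compound 1 `Cc1ccc(Nc2nnc(-c3ccccc3Cl)s2)cc1` gives 16700 nM. Compound 2 `CC(C)(C)c1ccc(-c2nnc(Nc3ccc(Br)cc3)s2)cc1` gives 32200 nM, the higher of the two numbers, though its gap to compound 1 lies within the scatter. Compound 3 `Cc1ccc(Nc2nnc(-c3ccc(C(C)(C)C)cc3)s2)cc1` differs from compound 2 by methyl in place of bromo on an aromatic carbon, para to a large group. Within the data shown here, no step of this kind has been measured, so in this assay the expected step is a 1.3-fold lower number from compound 2 to compound 3 (0.11 log units; within the scatter), none beyond the scatter. Compound 3 is therefore estimated at 25000 nM, within a range from 10000 nM to 60000 nM.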

Compound 3, half-maximal inhibitory concentration: 26300 nM
Compound 3: middle estimate off by 1.1-fold (0.02 log units), on the low side, within the range that was stated.
By their numbers in this assay, from the lowest: compounds 1, 3 and 2 (each within the scatter of the next).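

In this assay, among these compounds, this is the first single-place change read at this position, and going from 4-bromophenyl to 4-methylphenyl gives a 1.2-fold lower number from compound 2 to compound 3 (0.09 log units; within the scatter), so bromo and methyl on this aromatic carbon cannot be told apart here. With the large group held fixed, the exchange of one heavy atom for another leaves the reading within the scatter. Nothing available explains this result. As far as these compounds go, whether an amine, a carboxylic acid or a longer chain at this position would read differently remains open.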